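A few compounds are considered here, and "the series" means these few. Any claim that something is new, unique, unknown or untested is made for them only; others in the source may bear on it.

Compound 2 `COc1ccc(C(=O)Nc2cc(Nc3nccc(-c4cn(C)c5ccccc45)n3)c(OC)cc2F)nc1` stands with the highest number of the two compounds measured in a functional assay on NCI-H1975 cells (Homo sapiens) for antiproliferative activity, read by MTT assay, with a stated time of 72 h; a lower number here means a stronger inhibitor, a higher number a weaker inhibitor; it gives 16800 nM. For the measured compounds named here, its nearest neighbour, compound 1 `COc1cc(F)c(NC(=O)c2ccncc2OC)cc1Nc1nccc(-c2cn(C)c3ccccc23)n1`, gives 4120 nM in this assay, and the one measured step between them, a 4.1-fold higher number from compound 1 to compound 2 (0.61 log units; beyond the scatter), shows that exchanging the aromatic ring on the carbonyl carbon moves the number by a modest but real amount. Compound 3 `COc1cc(F)c(NC(=O)c2cnccn2)cc1Nc1nccc(-c2cn(C)c3ccccc23)n1` carries a further exchange at the same place: pyrazin-2-yl in place of 5-methoxypyridin-2-yl on a carbonyl carbon. Going by the values given here, the only step that bears on this change is the one already named, and it tells that such an exchange can shift the number in either direction by a modest amount. A shift of similar size, with no clear direction, is therefore expected here, so compound 3 is estimated at 9000 nM in this assay, within 2500 nM to 30000 nM, a step of a 1.9-fold lower number from compound 2 to compound 3 (0.27 log units; within the scatter).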

Compound 3, half-maximal inhibitory concentration: 24800 nM
For compound 3 the middle estimate is 2.8-fold (0.44 log units) below the measured one; the range from low to high includes it.
By their numbers in this assay, from the lowest: compound 1; then compounds 2 and 3 (each within the scatter of the next).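

In this assay the exchange of 5-methoxypyridin-2-yl for pyrazin-2-yl on the carbonyl carbon gives a 1.5-fold higher number from compound 2 to compound 3 (0.17 log units; within the scatter) so the two rings cannot be told apart, even though the entering ring has two hetero atoms and lacks the methoxy group. For the compounds shown here, measured against 3-methoxypyridin-4-yl, the pyrazin-2-yl group gives a 6.0-fold higher number from compound 1 to compound 3 (0.78 log units; beyond the scatter) and so, of the three rings at this position, only the one in compound 1 stands apart from the others, with the lowest number. No measured evidence accounts for this difference.

The compounds shown leave open how this position responds to a non-aromatic group on the carbonyl carbon, such as an amine or a longer chain. They also leave open whether any group here can improve on compound 1 at 4120 nM in this assay or whether the numbers stay in this range.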